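A few compounds are considered here, and "the series" means these few. Any claim that something is new, unique, unknown or untested is made for them only; others in the source may bear on it.

Working notes on the series. Among the compounds with values here, the three measured members are compound 1 `CC[C@@H]1C(=O)N(C)c2cnc(-n3ccc4cc(F)ccc43)nc2N1C1CCCC1`, compound 2 `CCC1C(=O)N(C)c2cnc(-n3ccc4cc(C(N)=O)ccc43)nc2N1c1ccn(C)n1` and compound 3 `CCC1C(=O)N(C)c2cnc(Nc3ccc(S(=O)(=O)NCCCO)cc3)nc2N1c1ccn(C)n1`. In a functional assay on K562 cells (Homo sapiens) for antiproliferative activity, read by CCK-8 assay, with a stated time of 72 h (a lower number here means a stronger inhibitor of growth, a higher number a weaker inhibitor of growth), compound 1 gives 21200 nM, compound 2 gives 31300 nM and compound 3 gives 13400 nM. Compound 3 holds the lowest of the three numbers; its gap to compound 1 falls within the scatter, so no order between those two can be read, while its gap to compound 2 lies beyond the scatter.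

Compound 4 `CCC1C(=O)N(C)c2cnc(Nc3ccc(S(=O)(=O)NCCO)cc3)nc2N1c1ccn(C)n1` has not been measured. It differs from compound 3 in one place: hydroxy in place of hydroxymethyl on a saturated chain carbon, two bonds along the chain from a sulfonamide nitrogen. Within the data shown here, no measured pair in the set carries a change of this kind, so there is no direct precedent for the size of the step. With only that to go on, no step beyond the scatter is expected in this assay, and the expected step of a 1.0-fold higher number from compound 3 to compound 4 (0.02 log units; within the scatter) is taken as essentially flat. Compound 4 is therefore estimated at 14000 nM, with a range from 7000 nM to 28000 nM.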

Compound 4, concentration for 50% growth inhibition: "not active" (no number reported)
Nothing numeric was reported for compound 4; the estimate stays without a comparison.
By their numbers in this assay, from the lowest: compounds 3, 1 and 2 (each within the scatter of the next, the first and the last beyond it).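

In this assay, within the data shown here, compound 4 is reported as "not active" without a number, so no step from compound 3 to compound 4 can be read. Going by these compounds, how far 3-hydroxypropyl to 2-hydroxyethyl on the sulfonamide nitrogen moves growth inhibition stays open, and no supporting data bear on this result.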